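The source may hold more compounds than are shown below. What is called first, only, known or untested is meant among the compounds shown, and "the series" means these compounds.

Compound 1, `CCOC(=O)CCCCOc1ccc2c(=O)c(-c3ccc(O)cc3)coc2c1`: 240 nM
Compound 2, `C=CCCCCOc1ccc2c(=O)c(-c3ccc(O)cc3)coc2c1`: 150 nM

Both compounds were tested in an assay (Cricetulus griseus) for inhibition of aldehyde dehydrogenase, mitochondrial (Homo sapiens); on this read-out higher numbers stand for weaker inhibition and lower numbers for stronger inhibition. Among the measured compounds shown here, compound 2 has the lowest of the two numbers, but the only step measured, a 1.6-fold lower number from compound 1 to compound 2 (0.20 log units; within the scatter), lies within the scatter, so the two compounds cannot be told apart on this read-out. That step exchanged an ethoxycarbonyl for a vinyl at the far end of a short chain attached through an oxygen to the shared core.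

Compound 3, `O=C(O)CCCCCCCCCOc1ccc2c(=O)c(-c3ccc(O)cc3)coc2c1`, keeps the core of compound 2 and changes the same end of the chain: 5-carboxypentyl in place of vinyl on a saturated chain carbon, four bonds along the chain from an oxygen on an aromatic ring. For the measured compounds named here, this is a different kind of change from the one already measured, since a much larger group with a hydrogen-bond donor and a hydrogen-bond acceptor replaces a small one, and nothing among the measured compounds shows how such an extension behaves. Going by the values given here, the one known step at this position, from compound 1 to compound 2, was small, which gives no reason to expect a large shift in either direction. For compound 3 the expected step is a 1.7-fold higher number from compound 2 to compound 3 (0.22 log units; within the scatter), and its value in this assay is estimated at 250 nM, with a range from 80 nM to 800 nM.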

Compound 3, half-maximal inhibitory concentration: 50 nM
For compound 3 the middle estimate is 5.0-fold (0.70 log units) above the measured one; the measured number lies below the stated range.
By their numbers in this assay, from the lowest: compound 3; then compounds 2 and 1 (each within the scatter of the next).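

Changing the end of this chain can shift the result in this assay, something the step between the first two compounds could not show. Replacing vinyl with the much larger 5-carboxypentyl group gives a modest step beyond the scatter (a 3.0-fold lower number from compound 2 to compound 3 (0.48 log units; beyond the scatter)), and replacing ethoxycarbonyl with it gives another (a 4.8-fold lower number from compound 1 to compound 3 (0.68 log units; beyond the scatter)), so compound 3 is the strongest inhibitor of the three. Nothing measured here explains why this change goes with stronger inhibition.

The change to compound 3 both extends the chain and places a carboxylic acid at its end, so the compounds shown leave open which of the two goes with the lower number. A chain of the same length ending in a plain methyl, an amine or a primary amide would help separate the two, while a shorter or longer chain still ending in a carboxylic acid would show how far the result depends on the distance of the acid from the shared core.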